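Working notes: one-carbon chain extension toward compound 3

A few compounds are considered here, and "the series" means these few. Any claim that something is new, unique, unknown or untested is made for them only; others in the source may bear on it.

compound 1 `CCCNC(=S)N1N=C(c2ccc(C)cc2)CC1c1ccc[nH]1` — 20.9%
compound 2 `CCNC(=S)N1N=C(c2ccc(OC)cc2)CC1c1ccc[nH]1` — 22.7%

In a functional assay on the whole organism (strain Swiss Albino) for inhibition, with Mus musculus as the target, read by paw edema, with a stated time of 180 min, at a dose of 100 mg/kg by the oral route (on this read-out higher numbers stand for more inhibition at the one dose given (going by the name of the read-out) and lower numbers for less inhibition), compound 2 gives 22.7%, the higher of the two numbers, and compound 1 gives 20.9%, a gap within the scatter, so no order between them can be read. Compound 3 `CCCNC(=S)N1N=C(c2ccc(OC)cc2)CC1c1ccc[nH]1` differs from compound 2 by methyl in place of hydrogen on a saturated chain carbon, two bonds along the chain from an amide-type nitrogen. Among the compounds with values here, no measured pair shows this change, so nothing beyond the scatter is expected; the step from compound 2 is estimated as a number 0.7 percentage points lower from compound 2 to compound 3 (within the scatter) in this assay. Compound 3 is expected to give 22%, within the range 12% to 32%.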

Compound 3, a percentage reported as inhibition, in the whole organism at one dose (the size of the read-out at that dose, not a potency): 23.6%
For compound 3 the middle estimate is 1.6 percentage points below the measured one; the range from low to high includes it.
By their numbers in this assay, from the lowest: compounds 1, 2 and 3 (each within the scatter of the next).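

In this assay, within the data shown here, ethylamino to propylamino gives a number 0.9 percentage points higher from compound 2 to compound 3 (within the scatter) and so the first measured pair at this position shows no readable effect of methyl in place of hydrogen on the chain. With propylamino held constant, methoxy in place of methyl on an aromatic carbon gives a number 2.7 percentage points higher from compound 1 to compound 3 (within the scatter) and likewise separates nothing. No supporting data bear on an explanation for either step. Going by these compounds, whether a longer chain such as butyl, or a terminal amine or carboxylic acid on the chain, would move the read-out beyond the scatter remains open.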